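The source may report more compounds than this note shows. Statements on the series, on what has been measured and on what is new or still open speak of the compounds shown alone.

Measured so far in a functional assay on MGC-803 cells (Homo sapiens) for inhibition, read by MTT assay, with a stated time of 72 h; a higher number here means a weaker inhibitor, a lower number a stronger inhibitor:
compound 1 `O=C(CSc1nc(Nc2ccccc2)c2ccccc2n1)Nc1ccccc1Cl`, 24800 nM;
compound 2 `O=C(CSc1nc(Nc2ccccc2)c2ccccc2n1)Nc1ccccc1Br`, 18600 nM;
compound 3 `O=C(CSc1nc(Nc2ccccc2)c2ccccc2n1)Nc1ccc(Cl)cc1`, 40400 nM.

Compound 4 `O=C(CSc1nc(Nc2ccccc2)c2ccccc2n1)Nc1ccc(Br)cc1` has not yet been measured. From compound 1 to compound 2 the change is bromo in place of chloro on an aromatic carbon, and the step was a 1.3-fold lower number from compound 1 to compound 2 (0.12 log units; within the scatter). The same kind of change leads from compound 3 to compound 4, namely (bromo in place of chloro on an aromatic carbon), though the place is not the same: here the halogen sits para to a large group rather than ortho to a large group. The core of compound 3 differs from that of compound 1 by 4-chlorophenyl in place of 2-chlorophenyl on an amide-type nitrogen, with a step of a 1.6-fold higher number from compound 1 to compound 3 (0.21 log units; within the scatter); between compound 2 and compound 3 the step was a 2.2-fold higher number from compound 2 to compound 3 (0.34 log units; beyond the scatter). Compound 4 is expected to show a step of about a 1.2-fold lower number from compound 3 to compound 4 (0.09 log units; within the scatter), because a 1.3-fold lower number from compound 1 to compound 2 (0.12 log units; within the scatter) stayed within the scatter. Compound 4 is therefore estimated at 33000 nM, with a likely range from 15000 nM to 70000 nM.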

Compound 4, half-maximal inhibitory concentration: 19300 nM
For compound 4 the middle estimate is 1.7-fold (0.23 log units) above the measured one; the range from low to high includes it.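

In this assay bromo in place of chloro on the second core gave a step reading a 2.1-fold lower number from compound 3 to compound 4 (0.32 log units; beyond the scatter), and set beside the earlier step, the change carried over from one core to the other with no difference in size beyond the scatter: the same change on two cores in this assay, a 1.3-fold lower number (0.12 log units; within the scatter) from compound 1 to compound 2 and a 2.1-fold lower number (0.32 log units; beyond the scatter) from compound 3 to compound 4, 1.6-fold (0.20 log units) apart, within the scatter of two such steps. The two bromo compounds also stand level, with a 1.0-fold higher number from compound 2 to compound 4 (0.02 log units; within the scatter), and the 4-bromophenyl compound stands level with the 2-chlorophenyl one, with a 1.3-fold lower number from compound 1 to compound 4 (0.11 log units; within the scatter). Two pairs in one cell assay do not show that the step has a fixed size, or that it would hold on any other core.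

The compounds shown leave open what fluoro, methoxy or a nitrile would do in place of the halogen. They also leave open what an amine or a carboxylic acid on the other phenyl ring of the shared core would do.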